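A few compounds are considered here, and "the series" means these few. Any claim that something is new, unique, unknown or untested is made for them only; others in the source may bear on it.

Measured in a functional assay on DU-145 cells (Homo sapiens) for antiproliferative activity, read by sulforhodamine B assay, with a stated time of 3 days; on this read-out higher numbers stand for weaker inhibition of growth and lower numbers for stronger inhibition of growth:
- Compound 1 `O=C(Nc1ccccn1)c1cccc(Nc2ncc(F)c(Nc3ccc(F)cc3)n2)c1`: 15100 nM
- Compound 2 `O=C(Nc1nccs1)c1cccc(Nc2ncc(F)c(Nc3ccc(F)cc3)n2)c1`: > 10000 nM (a limit)
- Compound 3 `COc1ccc(NC(=O)c2cccc(Nc3ncc(F)c(Nc4ccc(F)cc4)n3)c2)cc1`: > 10000 nM (a limit)

Compound 3 has no number in this assay, only the limit > 10000 nM. That is the limit of > 10000 nM in this assay, at which 2 of the 3 values shown sit. Compound 1 alone gives a number, 15100 nM.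

Compound 4 `O=C(Nc1cccc(Nc2ncc(F)c(Nc3ccc(F)cc3)n2)c1)c1cnccn1` replaces a whole side group of compound 3: ((pyrazin-2-yl)carbonyl)amino in place of (4-methoxyphenyl)carbamoyl on an aromatic carbon. In words, ((pyrazin-2-yl)carbonyl)amino stands in place of (4-methoxyphenyl)carbamoyl on an aromatic carbon.

The nearest measured changes all concern the group on the amide-type nitrogen: a step that the limit leaves unreadable from compound 1 to compound 2, a step that the limit leaves unreadable from compound 1 to compound 3 and a step that the two limits leave unreadable from compound 2 to compound 3. None has a readable size, and none covers the change made here. No step beyond the scatter can therefore be argued from them, so compound 4 is expected to stay in the same region as compound 1 with 15100 nM. The result for compound 4 may quite possibly be reported only as a limit. The expected step is a step that the limit leaves unreadable from compound 3 to compound 4. For compound 4 the estimated value is 14000 nM, with an expected range from 5000 nM to 40000 nM.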

Compound 4, concentration for 50% growth inhibition: 26400 nM
Compound 4: the middle estimate sits 1.9-fold (0.28 log units) below what was measured, and the stated range covers the measured number.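

In this assay, ((pyrazin-2-yl)carbonyl)amino in place of (pyridin-2-yl)carbamoyl on an aromatic carbon gives a 1.7-fold higher number from compound 1 to compound 4 (0.24 log units; within the scatter), so this change of the whole side group does not separate the two compounds. Among these compounds, compound 4 also supplies the second actual number, and it is the first readable comparison at this position. The steps to compound 4 from compound 2 and compound 3 cannot be read, because each of those two compounds has only a limit: the limit of > 10000 nM in this assay, at which 2 of the 4 values shown sit.

Compound 4 differs from compound 1 in both the direction of the amide and the ring, so the compounds shown do not tell these two changes apart. As far as these compounds go, it also remains open whether a carboxylic acid or a piperazine on this aromatic carbon would give a step beyond the scatter.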